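Swapping the aryl sulfonamide: from trifluoromethyl to chloro

The source may hold more compounds than are shown below. What is called first, only, known or untested is meant among the compounds shown, and "the series" means these compounds.

The shared core carries an ethyl ester, a benzyl group on a sulfonamide nitrogen and a sulfonyl-linked aromatic ring that varies. Compound 1 `CCOC(=O)c1oc2ccc(N(Cc3ccccc3)S(=O)(=O)c3cccc(Br)c3)cc2c1C` bears a 3-bromophenyl there, compound 2 `CCOC(=O)c1oc2ccc(N(Cc3ccccc3)S(=O)(=O)c3ccc(OC)cc3)cc2c1C` a 4-methoxyphenyl, and compound 3 `CCOC(=O)c1oc2ccc(N(Cc3ccccc3)S(=O)(=O)c3ccc(C(F)(F)F)cc3)cc2c1C` a 4-(trifluoromethyl)phenyl. Among the compounds with values here, in a functional assay on HCT-116 cells (Homo sapiens) for inhibition, read by MTT assay, with a stated time of 72 h (a lower number here means a stronger inhibitor, a higher number a weaker inhibitor), compound 3 gives 12700 nM, the only number in the set. Compound 1 reaches only the limit of the assay, > 40000 nM. Compound 2 likewise stops at the limit, > 40000 nM. Both limits sit at the same ceiling (the limit of > 40000 nM in this assay, at which 2 of the 3 values shown sit), so the steps of an at least 3.1-fold lower number from compound 1 to compound 3 (0.49 log units; beyond the scatter) and an at least 3.1-fold lower number from compound 2 to compound 3 (0.49 log units; beyond the scatter) are read as lower bounds, while the step that the two limits leave unreadable from compound 1 to compound 2 cannot be sized at all.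

Compound 4 `CCOC(=O)c1oc2ccc(N(Cc3ccccc3)S(=O)(=O)c3cccc(Cl)c3)cc2c1C` changes the same position: 3-chlorophenyl in place of 4-(trifluoromethyl)phenyl on a sulfonyl sulfur. In the sense of the group on the sulfonyl sulfur this is close to running the step from compound 1 to compound 3 backwards, since a 3-chlorophenyl is nearer to a 3-bromophenyl than to a 4-(trifluoromethyl)phenyl. Compound 4 is therefore expected to give a weaker result, with an estimated step of a 2.5-fold higher number from compound 3 to compound 4 (0.40 log units; beyond the scatter). The estimate for compound 4 is 32000 nM, with a range from 12000 nM to 90000 nM, and a real chance that the assay again reports only its limit.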

Compound 4, half-maximal inhibitory concentration: > 40000 nM
Compound 4: a limit, no number; the forecaster's own chance of this, stated with the estimate: 45%; middle value at least 1.2-fold (0.09 log units) away from the limit.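

In this assay, the move to 3-chlorophenyl gives an at least 3.1-fold higher number from compound 3 to compound 4 (0.49 log units; beyond the scatter), and that size is only a lower bound, for compound 4 gives a limit and not a number. Compound 4 joins compound 1 and compound 2 at the same ceiling, which leaves the 4-(trifluoromethyl)phenyl of compound 3 as the only group on the sulfonyl sulfur among these four that yields a number: the limit of > 40000 nM in this assay, at which 3 of the 4 values shown sit. The steps among compound 1, compound 2 and compound 4 cannot be read, so chloro in place of bromo shows no measurable change and no order can be given for these three.

On these data alone, compound 3 and compound 4 differ in both the group on the aromatic ring and its place there, so it remains open whether the trifluoromethyl group itself or its place in 4-(trifluoromethyl)phenyl sets compound 3 apart, a question that a 3-(trifluoromethyl)phenyl or a 4-chlorophenyl on the sulfonyl sulfur could address. As far as these compounds go, it also remains open whether an amine or a carboxylic acid on that ring would bring a number below the ceiling.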